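Pyridine N-oxide variant of a long-chain piperazine amide

The compounds below may be only part of what the source reports. "The series", "measured", "known", "first", "only" and "open" are said of these compounds alone.

Measured so far in an assay on HEK293 cells for displacement of a labelled ligand from 5-hydroxytryptamine receptor 7 (Rattus norvegicus); a higher number here means a weaker inhibitor, a lower number a stronger inhibitor:
compound 1 `O=C(CCCCCN1CCN(c2ccccc2-c2ccccc2)CC1)NC1CCCc2ccccc21`, 0.13 nM
compound 2 `Nc1ccccc1N1CCN(CCCCCC(=O)NC2CCCc3ccccc32)CC1`, 8180 nM
compound 3 `O=C(CCCCCN1CCN(c2ccccn2)CC1)NC1CCCc2ccccc21`, 278 nM

Compound 3 holds the second highest number of the three. Its nearest neighbour is compound 2, with a 29-fold lower number from compound 2 to compound 3 (1.47 log units; beyond the scatter); the most distant is compound 1, with a 2100-fold higher number from compound 1 to compound 3 (3.33 log units; beyond the scatter). The third comparison, a 63000-fold higher number from compound 1 to compound 2 (4.80 log units; beyond the scatter), shows how strongly this assay responds to what sits on the amine nitrogen in the ring.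

Compound 4 `O=C(CCCCCN1CCN(c2cccc[n+]2[O-])CC1)NC1CCCc2ccccc21` has not yet been measured. It differs from compound 3 in that (a group of 7 heavy atoms (5 carbon, 1 nitrogen, 1 oxygen; one six-membered aromatic ring with 1 hetero atom) in place of a group of 6 heavy atoms (5 carbon, 1 nitrogen; one six-membered aromatic ring with 1 hetero atom), on an amine nitrogen in a ring). Among the compounds with values here, no measured step alters the pyridin-2-yl group itself, so the only guidance is indirect: both a 2100-fold higher number from compound 1 to compound 3 (3.33 log units; beyond the scatter) and a 29-fold lower number from compound 2 to compound 3 (1.47 log units; beyond the scatter) are large, and each arises from replacing the group on that ring nitrogen. A change in that same place is therefore expected to move the number beyond the scatter, most likely upward, but with wide uncertainty. For compound 4 the estimate is 600 nM, within a range from 120 nM to 3000 nM. That estimate means an expected step of a 2.2-fold higher number from compound 3 to compound 4 (0.33 log units; beyond the scatter).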

Compound 4, inhibition constant: 8030 nM
For compound 4 the middle estimate is 13-fold (1.13 log units) below the measured one; the measured number lies above the stated range.
By their numbers in this assay, from the lowest: compound 1; then compound 3; then compounds 4 and 2 (each within the scatter of the next).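

In this assay, within the data shown here, the earlier steps replaced one whole group with another on the amine nitrogen in the ring, whereas a 29-fold higher number from compound 3 to compound 4 (1.46 log units; beyond the scatter) comes from a change within the pyridin-2-yl group: one oxygen enters, and the counts of hydrogen-bond donors and acceptors and the net charge stay the same. The step of a 1.0-fold lower number from compound 2 to compound 4 (0.01 log units; within the scatter) shows that the oxygen-bearing group and the 2-aminophenyl group, though they differ in their ring atoms, give numbers within the scatter of each other in this assay. The step of a 62000-fold higher number from compound 1 to compound 4 (4.79 log units; beyond the scatter) shows that this new group stays as far from the 2-phenylphenyl group as the 2-aminophenyl group does, so a small change at this position can cost about as much as removing the second phenyl ring.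

Nothing at hand bears on why the added oxygen has this effect. The compounds shown leave open whether a methyl group or a chlorine on the pyridine ring would also raise the number, and whether an unsubstituted phenyl ring or a 2-methoxyphenyl group would fall nearer to compound 1 or to compound 4.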